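The source may hold more compounds than are shown below. What is called first, only, known or untested is meant among the compounds shown, and "the series" means these compounds.

Measured so far:
- compound 1 `O/N=C(\CCN1CCN(c2ccccn2)CC1)c1cccc(F)c1`, 72%
- compound 2 `O/N=C(/CCN1CCN(c2ccccn2)CC1)c1cc(F)cc(F)c1`, 70%

In a functional assay on HEK293 cells with D(4) dopamine receptor (Homo sapiens) as the target, read by FLIPR (a lower number here means a smaller maximal response, a higher number a larger maximal response), compound 1 gives 72%. Among the compounds with values here, the only other measured compound is compound 2, and in this assay compound 2 gives 70%; the two numbers lie within the usual scatter of one another, so no order between compound 1 and compound 2 can be read from them. Both carry the same core with a fluorinated phenyl on the carbon with a double bond to nitrogen, and the two fluorination patterns so far have not moved the maximal response.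

Compound 3 `O/N=C(\CCN1CCN(c2ccccn2)CC1)c1ccc(F)cc1F` is the next variant and is not yet measured. It differs from compound 1 as follows: 2,4-difluorophenyl in place of 3-fluorophenyl on a carbon with a double bond to nitrogen. With only two data points, both close together, no step size beyond the scatter is expected in this assay; the expected step of a number 4 percentage points lower from compound 1 to compound 3 (within the scatter) is small. For compound 3 the estimate is 68%, with a range from 54% to 82%.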

Compound 3, largest response reached (reported as efficacy), in percent of the reference or control that the assay uses: 78%
Compound 3: the middle estimate sits 10 percentage points below what was measured; low and high end bracket the measured number.
By their numbers in this assay, from the lowest: compounds 2, 1 and 3 (each within the scatter of the next).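

Within the data shown here, the swap of 3-fluorophenyl for 2,4-difluorophenyl on the carbon with a double bond to nitrogen gives the first one-place step: in this assay, the result is a number 6 percentage points higher from compound 1 to compound 3 (within the scatter). The maximal response therefore holds through this change, which both adds a fluorine and alters the fluorination pattern on the phenyl, but this single step cannot separate those two parts of the change. No supporting data on the cause of this result are available.

Still open, as far as these compounds go, is whether the maximal response would hold with an unsubstituted phenyl, a chlorine or a methoxy group on the phenyl, or a pyridine in place of the phenyl. A longer chain from this carbon to the rest of the shared core also remains untested in the compounds shown here.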